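The source may hold more compounds than are shown below. What is called first, only, known or untested is meant among the compounds shown, and "the series" means these compounds.

Compounds measured so far in a functional assay on A549 cells (Homo sapiens) for antiproliferative activity, read by MTT assay, with a stated time of 72 h; on this read-out lower numbers stand for stronger inhibition and higher numbers for weaker inhibition:

Compound 1, `CN(C(=O)C(C)(C)C)c1ccc2[nH]c(-c3n[nH]c4ccccc34)cc2n1`: 24400 nM
Compound 2, `CN(C(=O)c1ccccc1)c1ccc2[nH]c(-c3n[nH]c4ccccc34)cc2n1`: 13800 nM
Compound 3, `CN(C(=O)c1ccc(Cl)cc1)c1ccc2[nH]c(-c3n[nH]c4ccccc34)cc2n1`: 2220 nM

Compound 3 gives the lowest number of the three, and its lead is beyond the scatter in both directions: a 6.2-fold lower number from compound 2 to compound 3 (0.79 log units; beyond the scatter) and an 11-fold lower number from compound 1 to compound 3 (1.04 log units; beyond the scatter). All three share the same core; they differ only in the group attached to the carbonyl carbon of the amide.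

Compound 4, `CN(C(=O)c1ccco1)c1ccc2[nH]c(-c3n[nH]c4ccccc34)cc2n1`, continues this series with another change at that same place: furan-2-yl in place of 4-chlorophenyl on a carbonyl carbon

For the measured compounds named here, two measured steps bear on this. The exchange of tert-butyl for phenyl gave a 1.8-fold lower number from compound 1 to compound 2 (0.25 log units; within the scatter), so an aromatic ring in place of a branched alkyl group made little difference here. The chloro on that ring then made the larger difference: a 6.2-fold lower number from compound 2 to compound 3 (0.79 log units; beyond the scatter). Compound 4 keeps an aromatic ring at the carbonyl but gives up the chloro, and a five-membered ring with one hetero atom replaces the six-membered carbon ring. Without a measured step for such a ring on this core, the expectation is anchored mainly on compound 2, whose 13800 nM shows what an unsubstituted aromatic ring at this position gives, and an increase in the number for compound 4 of about a 3.6-fold higher number from compound 3 to compound 4 (0.56 log units; beyond the scatter) is expected. Compound 4 is therefore estimated at 8000 nM, within a range of 2500 nM to 25000 nM.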

Compound 4, half-maximal inhibitory concentration: 15500 nM
Compound 4: the middle estimate sits 1.9-fold (0.29 log units) below what was measured; the measured number falls inside the stated range.
By their numbers in this assay, from the lowest: compound 3; then compounds 2, 4 and 1 (each within the scatter of the next).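

In this assay, replacing the 4-chlorophenyl with furan-2-yl gives up the advantage seen with compound 3 (a 7.0-fold higher number from compound 3 to compound 4 (0.84 log units; beyond the scatter)), so an aromatic ring on the carbonyl carbon is not enough by itself to keep the low number. The furan-2-yl group, with its five-membered ring and one hetero atom, cannot be told apart from the plain phenyl (a 1.1-fold higher number from compound 2 to compound 4 (0.05 log units; within the scatter)) or from the non-aromatic tert-butyl (a 1.6-fold lower number from compound 1 to compound 4 (0.20 log units; within the scatter)), so compounds 1, 2 and 4 now form a group within the scatter, and among the four groups at this position only the 4-chlorophenyl of compound 3 stands apart. The data shown offer no measurement that would explain why this one group differs from the other three.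

The compounds shown leave open whether the lower number depends on chlorine in particular or would also appear with another substituent on the phenyl ring, such as fluoro, methyl or methoxy. They also leave open what a chloro on the furan ring would give, and how a saturated ring such as cyclohexyl or a nitrogen-containing aromatic ring such as pyridyl would compare on the carbonyl carbon.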